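This account rests on a few compounds, and the source may have more. Where it says the series, first, only, none or still open, it means among the compounds named here.

Measured compounds:
compound 1 `CCc1cc(S(=O)(=O)N2C[C@H](c3ccccc3)NC2=O)ccc1NC(=O)c1ccc([N+](=O)[O-])cc1` — 800 nM
compound 2 `CCOC(=O)Nc1ccc(S(=O)(=O)N2C[C@H](c3ccccc3)NC2=O)cc1Cl` — 20 nM
compound 3 `CCOC(=O)Nc1ccc(S(=O)(=O)N2C[C@H](c3ccccc3)NC2=O)c(C)c1C` — 300 nM

In a functional assay on NCI-H460 cells (Homo sapiens) for cytotoxicity, read by MTT assay (a higher number here means a weaker inhibitor, a lower number a stronger inhibitor), compound 1 gives the highest of the three numbers. Compound 3 comes nearest to it with 300 nM, a gap beyond the scatter, and compound 2 lies furthest away with 20 nM, also well beyond the scatter. Both compound 2 and compound 3 carry an ethoxy in place of the 4-nitrophenyl on the carbonyl carbon, and both give lower numbers than compound 1; the ring substitution differs among all three, so the share of each part cannot be separated.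

Compound 4 `CCCOC(=O)Nc1ccc(S(=O)(=O)N2C[C@H](c3ccccc3)NC2=O)cc1CC` is not yet measured. It differs from compound 1 by propoxy in place of 4-nitrophenyl on a carbonyl carbon. Its ring carries an ethyl, as in compound 1. The step from compound 1 to compound 4 is expected to run downward in this assay, beyond the scatter, because compound 2 with 20 nM and compound 3 with 300 nM both sit below compound 1. For compound 4 the estimate is 80 nM, within 20 nM to 320 nM, a step of a 10-fold lower number from compound 1 to compound 4 (1.00 log units; beyond the scatter) that is expected rather than known.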

Compound 4, half-maximal inhibitory concentration: 60 nM
Compound 4: middle estimate off by 1.3-fold (0.12 log units), on the high side, and the stated range covers the measured number.
By their numbers in this assay, from the lowest: compound 2; then compound 4; then compound 3; then compound 1.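

In this assay, with the ethyl retained, propoxy in place of 4-nitrophenyl on a carbonyl carbon gives a 13-fold lower number from compound 1 to compound 4 (1.12 log units; beyond the scatter), a large step. Within the data shown here, this is the first comparison that isolates this change, since compound 2 and compound 3 also differ from compound 1 in their ring substitution. The lower number therefore belongs to the exchange of (4-nitrophenyl)carbonyl for propoxycarbonyl, at least with this ethyl in place, though nothing available explains why the number falls.

As far as these compounds go, whether the same exchange gives a similar step with the chloro of compound 2 or the two methyl groups of compound 3 remains open. Also open, from the compounds shown here alone, is how this carbonyl carbon responds to a methoxy, a longer chain such as butoxy, or an amine in place of propoxy.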